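Amino in place of acetyl on compound 1

The source may hold more compounds than are shown below. What is called first, only, known or untested is meant among the compounds shown, and "the series" means these compounds.

Among the compounds with values here, in a functional assay on HMEC-1 cells (Homo sapiens) for antiproliferative activity, read by cell counting, with a stated time of 4 days (on this read-out lower numbers stand for stronger inhibition and higher numbers for weaker inhibition), compound 1 (`CC(=O)c1ccc(Oc2ccccc2NC(C)=C2C(=O)CC(c3ccccc3)CC2=O)cc1`) gives 180 nM, the highest of the three numbers measured so far. Compound 2 (`CCOc1ccccc1NC(C)=C1C(=O)CC(c2ccccc2)CC1=O`) gives 100 nM, and compound 3 (`CC(Nc1ccccc1Oc1cccc(N)c1)=C1C(=O)CC(c2ccccc2)CC1=O`) gives 41 nM. Compound 4 (`CC(Nc1ccccc1Oc1ccc(N)cc1)=C1C(=O)CC(c2ccccc2)CC1=O`) has not been measured. It carries amino in place of acetyl on an aromatic carbon of compound 1, para to a large group: amino in place of acetyl on an aromatic carbon. The closest guide is the change to 3-aminophenyl, which gave a 4.4-fold lower number from compound 1 to compound 3 (0.64 log units; beyond the scatter). The change to ethyl gave a 1.8-fold lower number from compound 1 to compound 2 (0.26 log units; within the scatter), and 3-aminophenyl in place of ethyl gave a 2.4-fold lower number from compound 2 to compound 3 (0.39 log units; beyond the scatter). Within the data shown here, no measured compound carries 4-aminophenyl, so a modest drop of similar size is expected, a 3.6-fold lower number from compound 1 to compound 4 (0.56 log units; beyond the scatter). Compound 4 is estimated at 50 nM, with an expected range of 20 nM to 120 nM.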

Compound 4, half-maximal inhibitory concentration: 47 nM
Compound 4: middle estimate off by 1.1-fold (0.03 log units), on the high side, and the stated range covers the measured number.
By their numbers in this assay, from the lowest: compounds 3 and 4 (each within the scatter of the next); then compounds 2 and 1 (each within the scatter of the next).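

In this assay, within the data shown here, amino in place of acetyl para to a large group gives a 3.8-fold lower number from compound 1 to compound 4 (0.58 log units; beyond the scatter), about as large a step as the one to the 3-aminophenyl compound. Moving from 3-aminophenyl to 4-aminophenyl gives a 1.1-fold higher number from compound 3 to compound 4 (0.06 log units; within the scatter), so these two amino compounds cannot be told apart, while 4-aminophenyl in place of ethyl gives a 2.1-fold lower number from compound 2 to compound 4 (0.33 log units; beyond the scatter) and stays beyond the scatter. Nothing measured here explains these steps.

The compounds shown leave open whether a hydroxyl or a dimethylamino group at this place would match amino. They also leave open how plain phenyl, with no group there, would compare.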